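From 2-chlorophenyl to 4-fluorophenyl: working notes on the series

The source may report more compounds than this note shows. Statements on the series, on what has been measured and on what is new or still open speak of the compounds shown alone.

Of the compounds shown here, three have been read so far in a functional assay on the whole organism (strain Kunming) with Mus musculus as the target, with a stated time of 0.5 h (on this read-out higher numbers stand for an effect only at larger amounts of compound and lower numbers for an effect already at smaller amounts), and only one gives a number. Compound 1 `COc1ccccc1/C=C/C(=O)OC/C=C/c1cc(OC)c(OC)cc1OC` reports > 300 mg/kg as a limit. Compound 2 `COc1cc(OC)c(OC)cc1/C=C/COC(=O)/C=C/c1ccc(Br)cc1` reports > 300 mg/kg as a limit too. Compound 3 `COc1cc(OC)c(OC)cc1/C=C/COC(=O)/C=C/c1ccccc1Cl` gives 248 mg/kg as the only number shown. The series otherwise stands at the limit of > 300 mg/kg in this assay, at which 2 of the 3 values shown sit, for now. Among the compounds with values here, compound 4 `COc1cc(OC)c(OC)cc1/C=C/COC(=O)/C=C/c1ccc(F)cc1` follows from compound 3 through 4-fluorophenyl in place of 2-chlorophenyl on a double-bonded chain carbon bound to a double-bonded chain carbon as its one structural change. The steps bearing on it are an at least 1.2-fold lower number from compound 2 to compound 3 (0.08 log units; that floor lies within the scatter) and an at least 1.2-fold lower number from compound 1 to compound 3 (0.08 log units; that floor lies within the scatter) and neither shows a size beyond the scatter. The expected step is a 1.1-fold higher number from compound 3 to compound 4 (0.05 log units; within the scatter) with nothing beyond the scatter. For compound 4 the estimated value is 280 mg/kg with an expected range from 150 mg/kg to 500 mg/kg and a real chance of a limit instead.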

Compound 4, dose for half-maximal effect: > 300 mg/kg
Compound 4 was reported as a limit (the forecaster's own chance of this, stated with the estimate: 40%); middle value at least 1.0-fold (0.02 log units) away from the limit.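

Compound 4 reports a limit and adds no second number in this assay, so the 2-chlorophenyl of compound 3 remains the only group with one: the limit of > 300 mg/kg in this assay, at which 3 of the 4 values shown sit.

On a double-bonded chain carbon bound to a double-bonded chain carbon, the change gives an at least 1.2-fold higher number from compound 3 to compound 4 (0.08 log units; that floor lies within the scatter). The steps to compound 4 from compound 1 and compound 2 cannot be read, since both ends are limits.

Open, as far as these compounds go, is whether the number of compound 3 follows chlorine itself or its place, which a 4-chlorophenyl group would separate. Also open, from the compounds shown here alone, is whether a phenyl carrying an amine gives a number at all in this assay.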